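Mirror-Image Partner of a Potent Cyclohexane Sulfonamide

This account rests on a few compounds, and the source may have more. Where it says the series, first, only, none or still open, it means among the compounds named here.

Among the measured compounds shown here, in a functional assay on the whole organism with Mus musculus as the target, with a stated time of 20 min (a lower number here means that less compound is needed, a higher number that more compound is needed for the effect), compound 2 `CC(=O)N[C@H]1CC[C@H](NS(=O)(=O)c2ccc(F)cc2)CC1` gives 0.01 mg/kg, the lowest of the two numbers known. For the measured compounds named here, the only other measured compound, compound 1 `CC(C)S(=O)(=O)N1CCN2C(=O)CCC2C1`, needs far more: in this assay compound 1 gives 10 mg/kg, a gap beyond the scatter. Compound 3 `CC(=O)N[C@H]1CC[C@@H](NS(=O)(=O)c2ccc(F)cc2)CC1` is not yet measured. It differs from compound 2 in configuration only: the two compounds have the same atoms and bonds and differ only in configuration as drawn: 2 of 2 stereo elements differ (all stereocentres are inverted: mirror images); a stereocentre at a saturated ring carbon is drawn r in compound 2 and s in compound 3; a stereocentre at a saturated ring carbon is drawn r in compound 2 and s in compound 3. Going by the values given here, no step between measured compounds is known, so such a change is untested here; a step beyond the scatter toward a higher number is nevertheless expected, as a 10-fold higher number from compound 2 to compound 3 (1.00 log units; beyond the scatter). Compound 3 is expected to give 0.1 mg/kg, within 0.01 mg/kg to 3 mg/kg.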

Compound 3, minimum effective dose: 10 mg/kg
The estimate for compound 3 lay 100-fold (2.00 log units) below the measured number; the measured number lies above the stated range.
By their numbers in this assay, from the lowest: compound 2; then compounds 1 and 3 (each within the scatter of the next).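

Inverting both stereocentres at the saturated ring carbons gives a 1000-fold higher number from compound 2 to compound 3 (3.00 log units; beyond the scatter), so in this assay configuration alone separates a highly effective compound from a far less effective one. The earlier compounds offered no step of this kind, and here the gap can be traced to configuration because nothing else changes: the fact that compounds 2 and 3 differ only in the configuration as drawn

Going by these compounds, since both stereocentres differ at once, the contribution of each one remains unknown. On these data alone, it also remains open whether this dependence on configuration would persist with an amine or a carboxylic acid in place of the acetyl amide.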